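Cytotoxicity of a triaryl carbinol series on L6 cells

This account rests on a few compounds, and the source may have more. Where it says the series, first, only, none or still open, it means among the compounds named here.

In an ADME assay on L6 cells (Rattus norvegicus) for cytotoxicity, read by resazurin assay, with a stated time of 72 h (on this read-out higher numbers stand for weaker inhibition and lower numbers for stronger inhibition), compound 2 `Cc1ccccc1C(O)(c1ccc(Cl)cc1)c1cccnc1` gives 82000 nM. Compound 3 `COc1ccc(C(O)(c2ccc(Cl)cc2)c2cccnc2)cc1` gives 68100 nM and compound 1 `OC(c1ccc(Cl)cc1)(c1ccc(Br)cc1)c1cncnc1` gives 58700 nM; compound 2 stands with the highest of the three numbers, but both of its companions lie within the scatter, so the three compounds are indistinguishable on this read-out. Compound 4 `OC(c1ccc(Cl)cc1)(c1cccnc1)c1cnc(Cl)s1` has not yet been measured in this assay. It differs from compound 2 by 2-chloro-1,3-thiazol-5-yl in place of 2-methylphenyl on a saturated chain carbon bound to two aromatic carbons and an oxygen on a saturated carbon. Among the compounds with values here, with no measured pair of this kind to draw on, and three compounds sitting close together, the step is expected to stay within the scatter, with perhaps a slightly lower number. The estimated step is a 1.3-fold lower number from compound 2 to compound 4 (0.10 log units; within the scatter). Compound 4 is expected to give 65000 nM, within 30000 nM to 140000 nM.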

Compound 4, half-maximal inhibitory concentration: > 100000 nM
Compound 4: a limit, no number; the forecaster's own chance of this, stated with the estimate: 25%; middle value at least 1.5-fold (0.18 log units) away from the limit.
By their numbers in this assay, from the lowest: compounds 1, 3 and 2 (each within the scatter of the next). At a limit, above all of these: compound 4.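

For compound 4, this assay returns only a limit, > 100000 nM, and not a number. The exchange of 2-methylphenyl for 2-chloro-1,3-thiazol-5-yl gives an at least 1.2-fold higher number from compound 2 to compound 4 (0.08 log units; that floor lies within the scatter), so this position accepts a five-membered aromatic ring with 2 hetero atoms without a lower number appearing, though the true size of the step stays unread. This is the only compound of the series to read this way: the limit of > 100000 nM in this assay, at which 1 of the 4 values shown sits.

As far as these compounds go, how an amine or a carboxylic acid would read on this saturated chain carbon remains open. So does whether a plain thiazole without the chlorine would also reach the limit.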